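The source may hold more compounds than are shown below. What is called first, only, known or untested is meant among the compounds shown, and "the series" means these compounds.

Three measured compounds:
compound 1 `Cc1cn([C@@H]2O[C@H](CO[Si](C)(C)C(C)(C)C)[C@@]3(OS(=O)(=O)C=C3NC(N)=O)[C@H]2O[Si](C)(C)C(C)(C)C)c(=O)n(C)c1=O` — 4360 nM
compound 2 `Cc1cn([C@@H]2O[C@@H]3COC(=O)[C@]3(OS(C)(=O)=O)[C@H]2O)c(=O)[nH]c1=O` — 160000 nM
compound 3 `COC(=O)CNC1=CS(=O)(=O)O[C@@]12[C@@H](CO[Si](C)(C)C(C)(C)C)O[C@@H](n1cc(C)c(=O)n(C)c1=O)[C@@H]2O[Si](C)(C)C(C)(C)C` — 96000 nM

In a functional assay on CCRF-CEM cells (Homo sapiens) (a lower number here means that less compound is tolerated, a higher number that more compound is tolerated), compound 3 stands second highest of the three numbers; the gap to compound 2 is within the scatter, while compound 1 lies far lower. Among the compounds with values here, the only single-change step measured, a 22-fold higher number from compound 1 to compound 3 (1.34 log units; beyond the scatter), concerns a different place on the shared core and bears only loosely on what follows. Compound 4 `Cc1cn([C@@H]2O[C@H](CO[Si](C)(C)C(C)(C)C)[C@@]3(OS(=O)(=O)C=C3NCC(=O)O)[C@H]2O[Si](C)(C)C(C)(C)C)c(=O)n(C)c1=O` differs from compound 3 by hydrogen in place of methyl on an oxygen next to a carbonyl group. Within the data shown here, no measured pair shows this change, so the outlook rests on compound 3 alone. The step of a 1.6-fold higher number from compound 3 to compound 4 (0.19 log units; within the scatter) is expected to stay within the scatter or drift toward a higher number. Compound 4 is therefore estimated at 150000 nM, between 40000 nM and 600000 nM.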

Compound 4, half-maximal cytotoxic concentration: 65000 nM
The estimate for compound 4 lay 2.3-fold (0.36 log units) above the measured number; the measured number falls inside the stated range.
By their numbers in this assay, from the lowest: compound 1; then compounds 4, 3 and 2 (each within the scatter of the next, the first and the last beyond it).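

In this assay the change from methoxycarbonyl to carboxy gives a 1.5-fold lower number from compound 3 to compound 4 (0.17 log units; within the scatter) and so stays within the scatter: at this place, the methyl on the oxygen can go without a readable shift. The large gap to the carbamoyl compound also holds for the free acid, with a 15-fold higher number from compound 1 to compound 4 (1.17 log units; beyond the scatter) for carboxymethyl in place of carbamoyl on the amine nitrogen. No evidence is available to explain these numbers. As far as these compounds go, it remains open whether an amide or an amine at the end of this chain, or a longer chain bearing the carboxy group, would stay with compound 3 or move toward compound 1.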